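From 4-methoxyphenyl to 2-fluorophenyl on a sulfonyl sulfur

A few compounds are considered here, and "the series" means these few. Any claim that something is new, unique, unknown or untested is made for them only; others in the source may bear on it.

Measured so far in a functional assay on HEK293 cells (Homo sapiens) for cytotoxicity; on this read-out higher numbers stand for lower toxicity in this test and lower numbers for higher toxicity in this test:
- Compound 1 `COc1ccc([C@H]2CC(=O)N(c3cccc(NC(=O)C(C)=O)c3)C2)cc1OC1CCCC1`: > 10000 nM (a limit)
- Compound 2 `COc1ccc(S(=O)(=O)Nc2cccc(N3C[C@@H](c4ccc(OC)c(OC5CCCC5)c4)CC3=O)c2)cc1`: > 10000 nM (a limit)

Compound 2 gives > 10000 nM in this assay, which is a limit of the assay and not a number. Compound 1 gives > 10000 nM, and this too is only a limit. The whole picture so far is the limit of > 10000 nM in this assay, at which 2 of the 2 values shown sit, so no exact position can be given for compound 2.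

Compound 3 `COc1ccc([C@H]2CC(=O)N(c3cccc(NS(=O)(=O)c4ccccc4F)c3)C2)cc1OC1CCCC1` carries 2-fluorophenyl in place of 4-methoxyphenyl on a sulfonyl sulfur. For the measured compounds named here, the only measured change at this part of the molecule is a step that the two limits leave unreadable from compound 1 to compound 2, and it gives no size to carry forward. With nothing measured to suggest a shift, no step beyond the usual scatter and no direction is expected in this assay. The estimated step is a number no higher from compound 2 to compound 3 (the limit leaves the size open), a figure that rests on very little. For compound 3 the estimate is 10000 nM, with an expected range from 4000 nM to 20000 nM, and a report as a limit alone is the likeliest outcome.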

Compound 3, half-maximal cytotoxic concentration: > 10000 nM
Compound 3 was reported as a limit; the forecaster's own chance of this, stated with the estimate: 85%; the middle value lies on the limit itself.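

In this assay compound 3 gives > 10000 nM, which is a limit of the assay and not a number. No step from compound 1 or compound 2 to compound 3 can be read, as all of them sit at one limit: the limit of > 10000 nM in this assay, at which 3 of the 3 values shown sit.

The compounds shown leave open whether 2-fluorophenyl in place of 4-methoxyphenyl on the sulfonyl sulfur changes the result in this assay at all.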